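The source may report more compounds than this note shows. Statements on the series, on what has been measured and on what is new or still open speak of the compounds shown alone.

Of the compounds shown here, three have been tested in a functional assay on MCF7 cells (Homo sapiens) for cytotoxicity, read by MTT assay, with a stated time of 72 h; on this read-out higher numbers stand for weaker inhibition and lower numbers for stronger inhibition. Compound 1 `Cc1ccc2oc(CSc3nnc(C)s3)cc(=O)c2c1` gives > 25000 nM, which is a limit of the assay rather than a number. Compound 2 `Cc1ccc2oc(CSc3nnc(N)s3)cc(=O)c2c1` likewise gives > 25000 nM, a limit. Compound 3 `Nc1nnc(SCc2coc3ccccc3c2=O)s1` also gives > 25000 nM, again a limit. From compound 2 to compound 1 the change is methyl in place of amino on an aromatic carbon, and its step that the two limits leave unreadable from compound 2 to compound 1 cannot be read because of the limit of > 25000 nM in this assay, at which 3 of the 3 values shown sit. How the cores of compound 3 and compound 2 differ is not broken down here. Compound 4 `Cc1nnc(SCc2coc3ccccc3c2=O)s1` is not yet measured; it differs from compound 3 by methyl in place of amino on an aromatic carbon, the same change at the same place. Since compound 3 sits at its limit, as the limit of > 25000 nM in this assay, at which 3 of the 3 values shown sit, shows, compound 4 is expected to give about 40000 nM, likely as a limit too. The expected step is a step that the limit leaves unreadable from compound 3 to compound 4, resting on that same evidence.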

Compound 4, half-maximal inhibitory concentration: 6700 nM
The estimate for compound 4 lay 6.0-fold (0.78 log units) above the measured number; the whole stated range lies above it.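

In this assay, methyl in place of amino on the core of compound 3 gives an at least 3.7-fold lower number from compound 3 to compound 4 (0.57 log units; beyond the scatter), so on this core the change brings clearly stronger inhibition. The same change on the other core, from compound 2 to compound 1, cannot be read because both values are limits: the limit of > 25000 nM in this assay, at which 3 of the 4 values shown sit. Compound 1 gives > 25000 nM, which is a limit and not a number, so the result on one core stands as a single case and shows neither that the change carries over to the other core nor that it fails there.

On these data alone, it remains open whether another group at this place, such as ethyl, a longer chain or a carboxylic acid, would do better or worse than methyl. As far as these compounds go, it also remains open whether a plain hydrogen there would keep the activity of compound 4.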